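From methyl to ethyl at the assay limit

The compounds below may be only part of what the source reports. "The series", "measured", "known", "first", "only" and "open" are said of these compounds alone.

Measured in a functional assay on HOS cells (Homo sapiens) for antiproliferative activity, read by sulforhodamine B assay; a higher number here means a weaker inhibitor of growth, a lower number a stronger inhibitor of growth:
compound 1 `CC(C)C[C@@H]1O[C@H](COCc2ccccc2)[C@@H](OCc2ccccc2)[C@H](OCc2ccccc2)[C@H]1O`: 45200 nM
compound 2 `O[C@@H]1[C@@H](OCc2ccccc2)[C@H](OCc2ccccc2)[C@@H](COCc2ccccc2)O[C@H]1c1ccccc1`: > 50000 nM (a limit)
compound 3 `C[C@@H]1O[C@H](COCc2ccccc2)[C@@H](OCc2ccccc2)[C@H](OCc2ccccc2)C1=O`: > 50000 nM (a limit)

Compound 3 gives no number, only a limit, and sits at the limit of > 50000 nM in this assay, at which 2 of the 3 values shown sit. Compound 4 `CC[C@@H]1O[C@H](COCc2ccccc2)[C@@H](OCc2ccccc2)[C@H](OCc2ccccc2)C1=O` differs from it by methyl in place of hydrogen on a saturated chain carbon bound to a saturated ring carbon. Within the data shown here, only one measured step bears on this, and only loosely, since it is a change elsewhere: an at least 1.1-fold higher number from compound 1 to compound 2 (0.04 log units; that floor lies within the scatter). In this assay no step beyond the scatter is therefore expected, and the estimated step is a number no higher from compound 3 to compound 4 (the limit leaves the size open). Compound 4 is estimated at 50000 nM, with an expected range of 25000 nM to 100000 nM.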

Compound 4, concentration for 50% growth inhibition: 4300 nM
Beside the measured number, compound 4's estimate is 12-fold (1.07 log units) above it; measured number outside the range, below it.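

Methyl to ethyl at this place gives an at least 11-fold lower number from compound 3 to compound 4 (1.06 log units; beyond the scatter), the only step shown whose size lies beyond the scatter in this assay. The earlier compounds shown here did not show that growth inhibition responds to so small a change on this saturated chain carbon. How large the step truly is stays open, as compound 3 carries only a limit: the limit of > 50000 nM in this assay, at which 2 of the 4 values shown sit.

Going by these compounds, whether a propyl or longer chain at this place would lower the number further stays open. So does whether an amine on that chain would keep the effect.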